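The source may hold more compounds than are shown below. What is called first, only, known or untested is meant among the compounds shown, and "the series" means these compounds.

Of the compounds shown here, three with the same core have been measured in a functional assay on HL-60 cells (Homo sapiens) for cytotoxicity, read by MTT assay, with a stated time of 24 h; a lower number here means a stronger inhibitor, a higher number a weaker inhibitor. Compound 1 `BrCCCOc1c(Br)cc(Br)cc1Oc1ccc(Br)cc1Br` gives 29.9 ug/mL, compound 2 `BrCCCCOc1c(Br)cc(Br)cc1Oc1ccc(Br)cc1Br` gives 25.9 ug/mL, and compound 3 `CC(C)(C)C(=O)C(C#N)Oc1c(Br)cc(Br)cc1Oc1ccc(Br)cc1Br` gives 29.2 ug/mL. Compound 3 therefore cannot be told apart from the other two, as its gaps to both lie within the usual scatter.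

Compound 4 `Brc1ccc(Oc2cc(Br)cc(Br)c2OCc2ccccc2)c(Br)c1` keeps the core and exchanges one group, with benzyl in place of cyano((tert-butyl)carbonyl)methyl on an oxygen on an aromatic ring.

Among the compounds with values here, three measured steps bear on this, all made at that same oxygen: a 1.2-fold lower number from compound 1 to compound 2 (0.06 log units; within the scatter), a 1.0-fold lower number from compound 1 to compound 3 (0.01 log units; within the scatter) and a 1.1-fold higher number from compound 2 to compound 3 (0.05 log units; within the scatter). Each lies within the scatter. Within the data shown here, none of the measured compounds carries a ring on that oxygen, so the data offer only indirect guidance for benzyl. No step beyond the scatter is therefore expected in this assay, and the estimated step is a 1.0-fold lower number from compound 3 to compound 4 (0.02 log units; within the scatter). Compound 4 is expected to give about 28 ug/mL, with an estimated range of 15 ug/mL to 50 ug/mL.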

Compound 4, half-maximal inhibitory concentration: 27.9 ug/mL
Compound 4: middle estimate off by 1.0-fold (0.00 log units), on the high side; the measured number falls inside the stated range.
By their numbers in this assay, from the lowest: compounds 2, 4, 3 and 1 (each within the scatter of the next).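

Benzyl puts the first ring on this oxygen, and in this assay the change gives a 1.0-fold lower number from compound 3 to compound 4 (0.02 log units; within the scatter), so a six-membered aromatic ring of carbon only and the open-chain cyano((tert-butyl)carbonyl)methyl group cannot be told apart here, even though the ring carries no hydrogen-bond acceptors. The comparisons with the bromoalkyl chains agree, with a 1.1-fold higher number from compound 2 to compound 4 (0.03 log units; within the scatter) and a 1.1-fold lower number from compound 1 to compound 4 (0.03 log units; within the scatter), so phenyl on the saturated chain carbon bound to that oxygen also leaves the number within the scatter of both chains. Nothing shown explains why such different groups give indistinguishable numbers.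

From the compounds shown here alone, whether any group on this oxygen can move the number beyond the scatter remains open. An amine or a carboxylic acid on that chain, or a free hydroxyl on the ring in place of the ether, could settle this.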